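Swapping methyl for chloro on the outer phenyl ring

This account rests on a few compounds, and the source may have more. Where it says the series, first, only, none or still open, it means among the compounds named here.

Compound 1 `Cc1ccc(-c2ccnc(C(=O)Nc3ccc(Oc4ccnc5[nH]ccc45)cc3)n2)cc1`: 6140 nM
Compound 2 `Cc1ccc(-c2ccnc(C(=O)Nc3ccc(Oc4ccnc5[nH]ccc45)c(F)c3)n2)cc1`: 520 nM

Of the compounds shown here, two have been measured in a functional assay on PC-3 cells (Homo sapiens) for cytotoxicity, read by MTT assay, with a stated time of 72 h; a lower number here means a stronger inhibitor, a higher number a weaker inhibitor. Compound 1 gives 6140 nM and compound 2 gives 520 nM, so compound 2 stands with the lowest number of the two; the step between them is a 12-fold lower number from compound 1 to compound 2 (1.07 log units; beyond the scatter). That step came from a fluoro in place of hydrogen on an aromatic carbon.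

Compound 3 `O=C(Nc1ccc(Oc2ccnc3[nH]ccc23)c(F)c1)c1nccc(-c2ccc(Cl)cc2)n1` keeps the fluorine of compound 2 and changes a different part: chloro in place of methyl on an aromatic carbon. Among the measured compounds shown here, no measured step touches this position; the only step known is the one from compound 1 to compound 2, and it concerns the fluorine, not the methyl-bearing ring. There is therefore nothing in the numbers that points to a change in either direction, and a step within the usual scatter is the most reasonable expectation, with both a slightly lower and a slightly higher number remaining plausible.

On that basis compound 3 is expected to give about 500 nM, within the range 150 nM to 1500 nM, which corresponds to an estimated step of a 1.0-fold lower number from compound 2 to compound 3 (0.02 log units; within the scatter).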

Compound 3, half-maximal inhibitory concentration: 14600 nM
Estimate against measurement, compound 3: 29-fold (1.47 log units) below; the whole stated range lies below it.
By their numbers in this assay, from the lowest: compound 2; then compound 1; then compound 3.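

In this assay, among the compounds shown here, replacing 4-methylphenyl with 4-chlorophenyl gives a 28-fold higher number from compound 2 to compound 3 (1.45 log units; beyond the scatter), so this outer ring position, which no earlier step had touched, turns out to be highly sensitive to a change of a single heavy atom. The fluorine is present in both compounds and the rest of the structure is unchanged, so this step belongs entirely to the swap of methyl for chloro, and it runs in the opposite direction to the earlier change elsewhere in the molecule, a 12-fold lower number from compound 1 to compound 2 (1.07 log units; beyond the scatter). No measurement available here explains why chloro at this position gives so much weaker a result than methyl.

The compounds shown leave open whether methyl is especially favourable here or chloro especially unfavourable, a question that hydrogen, methoxy, an amine or a longer chain such as ethyl at the same position could help to settle. They also leave open whether the swap of methyl for chloro would have a step of similar size in a compound that lacks the fluorine, as the two changes have so far been seen only one after the other.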